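A Fluorophenyl Amide Next to Three Relatives at the Limit

A few compounds are considered here, and "the series" means these few. Any claim that something is new, unique, unknown or untested is made for them only; others in the source may bear on it.

Compound 1 `COc1ccc2c(=O)c(/C=C/C(=O)NCc3ccccc3)coc2c1` is the reference. In a functional assay on L02 cells (Homo sapiens) for inhibition, read by MTT assay, with a stated time of 48 h (on this read-out higher numbers stand for weaker inhibition and lower numbers for stronger inhibition), compound 1 gives only a limit of the assay, > 200000 nM. Compound 2 `COc1ccc2c(=O)c(/C=C/C(=O)NCc3ccc(C)cc3)coc2c1` carries methyl in place of hydrogen on an aromatic carbon, and in this assay compound 2 likewise reaches only a limit, > 200000 nM. Compound 3 `COc1ccc2c(=O)c(/C=C/C(=O)Nc3ccc(Cl)cc3)coc2c1` carries 4-chlorophenyl in place of benzyl on an amide-type nitrogen, and in this assay compound 3 also stops at a limit, > 200000 nM. Accordingly (the limit of > 200000 nM in this assay, at which 3 of the 3 values shown sit), and the steps a step that the two limits leave unreadable from compound 1 to compound 2, a step that the two limits leave unreadable from compound 1 to compound 3 and a step that the two limits leave unreadable from compound 2 to compound 3 cannot be sized.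

Compound 4 `COc1ccc2c(=O)c(/C=C/C(=O)Nc3ccc(F)cc3)coc2c1` differs from compound 1 by 4-fluorophenyl in place of benzyl on an amide-type nitrogen. Among the compounds with values here, the most closely related measured step is the one from compound 1 to compound 3, but it is unreadable, so the measured steps give neither a direction nor a size for the change to compound 4. Compound 4 is therefore expected to sit near 300000 nM, within 100000 nM to 1000000 nM, and most probably to be reported only as a limit. The expected step that the limit leaves unreadable from compound 1 to compound 4 is thus estimated as no change beyond the scatter.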

Compound 4, half-maximal inhibitory concentration: > 200000 nM
Compound 4: a limit, no number; the forecaster's own chance of this, stated with the estimate: 85%; the middle value is on the limit's open side.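

Within the data shown here, no step from compound 1, compound 2 or compound 3 to compound 4 can be read in this assay, because all four compounds stop at a limit: the limit of > 200000 nM in this assay, at which 4 of the 4 values shown sit.

The compounds shown leave open what number any of them would reach, and so whether benzyl, 4-methylbenzyl, 4-chlorophenyl and 4-fluorophenyl on the amide-type nitrogen differ at all on this read-out.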